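Swapping Bromo for Ethoxy on an Aromatic Ring

The source may report more compounds than this note shows. Statements on the series, on what has been measured and on what is new or still open speak of the compounds shown alone.

Of the compounds shown here, three sharing one core have been tested in a functional assay on ECa-109 cells for inhibition, with ECa-109 cell line (Homo sapiens) as the target, read by sulforhodamine B assay; a lower number here means a stronger inhibitor, a higher number a weaker inhibitor. Compound 1 `O=C1C=C(NCc2ccccc2)C(=O)c2c1nc1n2[C@H]2OC[C@@H](O)[C@H]2OC1`, with a benzyl group on an amine nitrogen, gives > 8000 nM, which is a limit of the assay and not a number. Compound 2 `O=C1C(Nc2ccc(Br)cc2)=CC(=O)c2c1nc1n2[C@H]2OC[C@@H](O)[C@H]2OC1`, with a 4-bromophenyl group, gives 1980 nM. Compound 3 `CCc1ccc(NC2=CC(=O)c3nc4n(c3C2=O)[C@H]2OC[C@@H](O)[C@H]2OC4)cc1`, with a 4-ethylphenyl group, gives 3080 nM, so compound 2 and compound 3 stand level within the scatter.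

Compound 4 `CCOc1ccc(NC2=CC(=O)c3c(nc4n3[C@H]3OC[C@@H](O)[C@H]3OC4)C2=O)cc1` has not yet been measured. It differs from compound 2 in one place: ethoxy in place of bromo on an aromatic carbon. Ethoxy takes the place of bromo on an aromatic carbon, para to a large group.

Within the data shown here, the one measured step, an at least 2.5-fold lower number from compound 1 to compound 3 (0.41 log units; beyond the scatter), swaps benzyl for 4-ethylphenyl, so it only loosely guides a change of bromo to ethoxy. The closer guide is a comparison of two values: compound 2 at 1980 nM and compound 3 at 3080 nM carry different groups at this same place, yet stay within the scatter. No step beyond the scatter is therefore expected in this assay. The expected change is small, a 1.3-fold higher number from compound 2 to compound 4 (0.12 log units; within the scatter). For compound 4 the estimated value is 2600 nM, with an expected range from 1100 nM to 6000 nM.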

Compound 4, half-maximal inhibitory concentration: > 4000 nM
Compound 4 gave a limit, no number (the forecaster's own chance of this, stated with the estimate: 15%); at least 1.5-fold (0.18 log units) between middle value and limit.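

In this assay compound 4 gives a limit of the assay and not a number: the limit of > 4000 nM in this assay, at which 1 of the 4 values shown sits. From the compounds shown here alone, the change from bromo to ethoxy therefore comes with only a floor, an at least 2.0-fold higher number from compound 2 to compound 4 (0.30 log units; that floor lies within the scatter), and since that floor does not clear the usual scatter, it does not by itself separate the two compounds, while the true size of the step stays unknown. What is new is that, of the three compounds carrying a substituted phenyl group, 4-bromophenyl in compound 2 and 4-ethylphenyl in compound 3 gave numbers, whereas 4-ethoxyphenyl in compound 4 gave only a limit, so this place on the ring does not accept every group with a measurable result.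

The compounds shown leave open whether the oxygen of the ethoxy group or its two-carbon chain goes with this outcome. A methoxy group, a hydroxyl or a propyl chain at the same place, each read as a number and not a limit, would begin to tell these apart.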